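This account rests on a few compounds, and the source may have more. Where it says the series, first, only, none or still open, it means among the compounds named here.

Compound 1 `Cc1ncc(-c2ccccc2NCC2=NCCN2)o1`: in a functional assay for activation of Alpha-1D adrenergic receptor (Homo sapiens) (a lower number here means that less compound is needed, a higher number that more compound is needed for the effect), compound 1 gives < 5020 nM, which is a limit of the assay and not a number.
Compound 2 `Cc1nc(-c2ccccc2NCC2=NCCN2)cs1`: in this assay compound 2 gives < 5020 nM, likewise only a limit.

Compound 2 therefore stands at the limit of < 5020 nM in this assay, at which 2 of the 2 values shown sit, with no exact value of its own. Among the compounds with values here, the single measured step, a step that the two limits leave unreadable from compound 1 to compound 2, cannot be read for size. Compound 3 `c1csc(-c2ccccc2NCC2=NCCN2)c1` differs from compound 2 by thiophen-2-yl in place of 2-methyl-1,3-thiazol-4-yl on an aromatic carbon. With no readable step to lean on, a change of no more than the usual scatter is expected, a step that the limit leaves unreadable from compound 2 to compound 3. Compound 3 is thus estimated at 1500 nM in this assay, within 250 nM to 5000 nM.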

Compound 3, half-maximal effective concentration: 18.2 nM
Beside the measured number, compound 3's estimate is 82-fold (1.92 log units) above it; measured number outside the range, below it.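

None of the steps linking compound 1, compound 2 and compound 3 can be read for size, as compound 1 and compound 2 have only assay limits, not numbers: the limit of < 5020 nM in this assay, at which 2 of the 3 values shown sit.

The compounds shown leave open how far compound 3 truly lies from compound 1 and compound 2 in this assay.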